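A Thiophene Swap at the Assay Limit

The source may report more compounds than this note shows. Statements on the series, on what has been measured and on what is new or still open speak of the compounds shown alone.

In a functional assay on CEM-DNR-bulk cells (Homo sapiens), read by MTT assay, with a stated time of 72 h (on this read-out higher numbers stand for weaker inhibition and lower numbers for stronger inhibition), compound 3 (`COc1nc(N)nc2c1c(-c1ccoc1)cn2[C@@H]1O[C@H](CO)[C@@H](O)[C@H]1O`) gives only a limit, > 20000 nM, and not a number. Compound 2 (`COc1nc(N)nc2c1c(-c1ccco1)cn2[C@@H]1O[C@H](CO)[C@@H](O)[C@H]1O`) likewise gives only a limit, > 20000 nM. Compound 1 (`Nc1nc(N)c2c(-c3cccs3)cn([C@@H]3O[C@H](CO)[C@@H](O)[C@H]3O)c2n1`), which carries thiophen-2-yl, also gives only a limit, > 20000 nM. The three measured compounds thus share one position in this assay: the limit of > 20000 nM in this assay, at which 3 of the 3 values shown sit.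

Compound 4 (`COc1nc(N)nc2c1c(-c1cccs1)cn2[C@@H]1O[C@H](CO)[C@@H](O)[C@H]1O`) differs from compound 3 by a single exchange, thiophen-2-yl in place of furan-3-yl on an aromatic carbon.

For the measured compounds named here, the one measured step that bears on this exchange, a step that the two limits leave unreadable from compound 2 to compound 3, offers no size to carry over. Going by the values given here, the only other guide is compound 1, whose limit of > 20000 nM shows that thiophen-2-yl on its core brought no readable number. On this evidence no change beyond the scatter is expected in either direction, and the estimated step is a number no higher from compound 3 to compound 4 (the limit leaves the size open). A report of only a limit is expected to be the most likely outcome. For compound 4 the estimated value is 20000 nM, with an expected range from 7000 nM to 40000 nM.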

Compound 4, half-maximal inhibitory concentration: > 20000 nM
Compound 4 ended at the assay's limit; the forecaster's own chance of this, stated with the estimate: 75%; the middle value lies on the limit itself.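

Compound 4 gives only a limit in this assay, so no step linking it to compound 1, compound 2 or compound 3 can be read: the limit of > 20000 nM in this assay, at which 4 of the 4 values shown sit.

The compounds shown leave open whether thiophen-2-yl, furan-2-yl and furan-3-yl, or methoxy and amino, differ at all in this assay.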